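The compounds below may be only part of what the source reports. "The series", "measured", "known", "first", "only" and "open" are said of these compounds alone.

In a functional assay on KB cells (Homo sapiens) for antiproliferative activity, read by sulforhodamine B assay, with a stated time of 3 days (a lower number here means that less compound is needed, a higher number that more compound is needed for the effect), compound 1 (`CCC1=C(O)c2c(oc(-c3ccc(CC)cc3)cc2=O)C(CC)(CC)C1=O`) gives 21.9 uM and compound 2 (`CCC1=C(O)c2c(oc(-c3cccc(C)c3)cc2=O)C(CC)(CC)C1=O`) gives 49.7 uM as the higher of the two numbers, so compound 2 needs more compound for the same effect. Compound 3 (`CCC1=C(O)c2c(oc(-c3cccc(OC)c3)cc2=O)C(CC)(CC)C1=O`) keeps the shared core and carries methoxy in place of methyl on an aromatic carbon, turning 3-methylphenyl into 3-methoxyphenyl. The counted difference is methoxy in place of methyl on an aromatic carbon and nothing else changes. Within the data shown here, no measured pair tests this exact swap. The closest guide is a 2.3-fold higher number from compound 1 to compound 2 (0.36 log units; beyond the scatter) on the same aromatic substituent, and that step is modest even though it changes both the group and its place. A similar or smaller step is therefore expected here, with no clear direction, and the estimated change of a 1.1-fold lower number from compound 2 to compound 3 (0.04 log units; within the scatter) is expected to stay within the scatter. In this assay the estimated value for compound 3 is 45 uM with an expected range from 20 uM up to 100 uM as its upper end.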

Compound 3, concentration for half-maximal effect: 13.3 uM
For compound 3 the middle estimate is 3.4-fold (0.53 log units) above the measured one; measured number outside the range, below it.
By their numbers in this assay, from the lowest: compounds 3 and 1 (each within the scatter of the next); then compound 2.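

In this assay, the step of a 3.7-fold lower number from compound 2 to compound 3 (0.57 log units; beyond the scatter) shows that this place on the aromatic ring responds to a small change: methoxy in place of methyl, a swap of only one added oxygen, moves the number beyond the scatter. The step of a 1.6-fold lower number from compound 1 to compound 3 (0.22 log units; within the scatter) puts 3-methoxyphenyl and 4-ethylphenyl level with each other, so of these three compounds, compound 2 with its 3-methylphenyl is the one that stands apart from both others. No measurement at hand accounts for the effect of this swap.

On these data alone, it remains open whether a hydroxyl group, an amine or a longer chain such as ethoxy in the same place would lower the number further or raise it again. As far as these compounds go, it is also open whether methoxy would give a similar number in the place that ethyl holds in compound 1.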